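From cyclopropyl to 4-fluorophenyl on the aromatic nitrogen

A few compounds are considered here, and "the series" means these few. Any claim that something is new, unique, unknown or untested is made for them only; others in the source may bear on it.

For the measured compounds named here, in an ADME assay on Vero cells (Chlorocebus sabaeus) for cytotoxicity, read by MTT assay, with a stated time of 72 h (a lower number here means a stronger inhibitor, a higher number a weaker inhibitor), compound 1 `O=C(O)c1cn(C2CC2)c2nc(N3CCN(C(=O)C4COc5ccccc5O4)CC3)c([N+](=O)[O-])cc2c1=O` gives 59900 nM as the lowest number so far. Compound 3 `CN1CCN(c2nc3c(cc2[N+](=O)[O-])c(=O)c(C(=O)O)cn3-c2ccc(F)cc2)CC1c1ccccc1` gives 124000 nM and is the nearest, higher by more than the scatter. For compound 2 `CCN(CC)C(=O)C1CCCN(c2nc3c(cc2[N+](=O)[O-])c(=O)c(C(=O)O)cn3C2CC2)C1` the reading of > 136000 nM is a limit of the assay and not a number.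

Compound 4 `O=C(O)c1cn(-c2ccc(F)cc2)c2nc(N3CCN(C(=O)C4COc5ccccc5O4)CC3)c([N+](=O)[O-])cc2c1=O` departs from compound 1 in one place, with 4-fluorophenyl in place of cyclopropyl on an aromatic nitrogen (the counted change). Going by the values given here, no measured pair isolates this exchange, so the expectation rests on little. Compound 3 also bears 4-fluorophenyl on that nitrogen and gives 124000 nM in this assay, which gives some reason to lean toward a higher number. Even so, no change beyond the scatter is expected, and the estimated step is a 1.3-fold higher number from compound 1 to compound 4 (0.10 log units; within the scatter) in the same direction. For compound 4 the estimated value is 75000 nM (expected range 35000 nM to 150000 nM).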

Compound 4, half-maximal inhibitory concentration: > 54300 nM
Compound 4: a limit, no number (the forecaster's own chance of this, stated with the estimate: 10%); the middle value does not contradict the limit.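

In this assay compound 4 gives > 54300 nM, which is a limit and not a number, so the step to it from compound 1 cannot be read. The compounds shown leave open whether 4-fluorophenyl in place of cyclopropyl on an aromatic nitrogen changes the number in this assay at all.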